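Working notes: lengthening the chain of compound 2

The source may report more compounds than this note shows. Statements on the series, on what has been measured and on what is new or still open speak of the compounds shown alone.

Of the compounds shown here, two have numbers so far in a functional assay on MCF-10A cells (Homo sapiens) for antiproliferative activity, with a stated time of 48 h; on this read-out higher numbers stand for an effect only at larger amounts of compound and lower numbers for an effect already at smaller amounts. Compound 1 `COc1ccc2nc(C)cc(SCc3ccc(F)cc3)c2c1` gives 50500 nM. Compound 2 `CCCOc1ccc2nc(C)cc(NCc3ccc(F)cc3)c2c1` gives 14300 nM, the lower number of the two, and the gap between them lies beyond the usual scatter. Compound 3 `CCCCCCCCOc1ccc2nc(C)cc(NCc3ccc(F)cc3)c2c1` has not yet been measured. Relative to compound 2, it carries pentyl in place of hydrogen on a saturated chain carbon, three bonds along the chain from an oxygen on an aromatic ring. Cut one bond further out, the same difference reads propyl to octyl. Within the data shown here, no measured pair shows a change of this kind, and the direction remains uncertain. A moderate step to a lower number in this assay is expected, only a little beyond the scatter. The expected step is a 2.4-fold lower number from compound 2 to compound 3 (0.38 log units; beyond the scatter). The estimated value for compound 3 is 6000 nM, with an expected range from 1500 nM to 25000 nM.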

Compound 3, half-maximal effective concentration: 2200 nM
Beside the measured number, compound 3's estimate is 2.7-fold (0.44 log units) above it; measured number inside the range.
By their numbers in this assay, from the lowest: compound 3; then compound 2; then compound 1.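

In this assay, the series now has its first pair differing in one place: propyl to octyl gives a 6.5-fold lower number from compound 2 to compound 3 (0.81 log units; beyond the scatter). This shows that the saturated chain carbon three bonds along the chain from an oxygen on an aromatic ring accepts pentyl in place of hydrogen, and that the number moves towards an effect at smaller amounts. No available evidence bears on the reason for this step.

The two chain lengths shown leave open whether the number falls gradually through the lengths between propyl and octyl, or whether the direction holds for a longer chain such as dodecyl. They also leave open whether a chain ending in an amine or a carboxylic acid would follow the same direction.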